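Chloro to fluoro on the aromatic ring of compound 1

This account rests on a few compounds, and the source may have more. Where it says the series, first, only, none or still open, it means among the compounds named here.

Compound 1 `CCCSc1nc(C(CC)c2c(F)cccc2Cl)c(C)c(=O)[nH]1` is the starting point in an ADME assay on MT4 cells (Homo sapiens) for activation, read by MTT assay; a lower number here means that less compound is tolerated, a higher number that more compound is tolerated. Compound 1 gives > 3000 nM, which is a limit of the assay and not a number. Its neighbour, compound 2 `CCC(C)Sc1nc(C(CC)c2c(F)cccc2Cl)c(C)c(=O)[nH]1`, gives > 3000 nM, likewise a limit. Both measured compounds therefore share (the limit of > 3000 nM in this assay, at which 2 of the 2 values shown sit).

Compound 3 `CCCSc1nc(C(CC)c2c(F)cccc2F)c(C)c(=O)[nH]1` departs from compound 1 in one place: fluoro in place of chloro on an aromatic carbon.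

Within the data shown here, the only measured step is a step that the two limits leave unreadable from compound 1 to compound 2. It lies at a different place in the molecule and offers no size to carry over to this change. Compound 1 remains the only anchor, and its reading of > 3000 nM is a limit, so no step beyond the scatter is expected in this assay, in either direction.

The estimated step is a step that the limit leaves unreadable from compound 1 to compound 3. For compound 3 the expected value is 6000 nM, with an estimated range from 3000 nM to 50000 nM.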

Compound 3, half-maximal cytotoxic concentration: > 3000 nM
Compound 3 ended at the assay's limit; the forecaster's own chance of this, stated with the estimate: 75%; the middle value is on the limit's open side.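

In this assay compound 3 gives > 3000 nM, which is a limit of the assay and not a number. No step can be read for compound 3 against compound 1, as the whole series stands at one limit: the limit of > 3000 nM in this assay, at which 3 of the 3 values shown sit.

The compounds shown leave open whether fluoro in place of chloro on the aromatic ring changes the half-maximal cytotoxic concentration at all.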